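Iodo removal on two fused five-membered cores

A few compounds are considered here, and "the series" means these few. Any claim that something is new, unique, unknown or untested is made for them only; others in the source may bear on it.

Compound 1 `Cn1c(I)nc2ccccc21` was tested in a functional assay on HCT-116 cells (Homo sapiens) for cytotoxicity, with a stated time of 3 days (on this read-out lower numbers stand for stronger inhibition and higher numbers for weaker inhibition), where compound 1 gives 17500 nM. Compound 2 `Cn1cnc2ccccc21` is the hydrogen analogue. In this assay compound 2 reaches only a limit, > 40000 nM. The change hydrogen in place of iodo on an aromatic carbon gives an at least 2.2-fold higher number from compound 1 to compound 2 (0.35 log units; beyond the scatter). Compound 3 `Ic1nc2ccccc2[se]1` carries the same iodo on a different core; the difference between the two cores is not broken down here. In this assay compound 3 reaches only a limit, > 40000 nM. Compound 4 `c1ccc2[se]cnc2c1` has not been measured; it differs from compound 3 by hydrogen in place of iodo on an aromatic carbon. This is the same kind of change as from compound 1 to compound 2, though the surroundings differ: in compound 1 the carbon sits between two ring nitrogen atoms, next to the ring atom that bears a methyl group, whereas in compound 3 it sits next to the ring nitrogen and next to the ring selenium. Compound 4 is expected to give a step that the limit leaves unreadable from compound 3 to compound 4 in this assay; this rests on the limit of > 40000 nM in this assay, at which 2 of the 3 values shown sit, and on the weakening seen in an at least 2.2-fold higher number from compound 1 to compound 2 (0.35 log units; beyond the scatter). Compound 4 is thus estimated at 60000 nM, most likely reported as a limit again.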

Compound 4, half-maximal inhibitory concentration: > 40000 nM
Compound 4: no number, only a limit; the forecaster's own chance of this, stated with the estimate: 85%; the middle value lies beyond the limit too.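

Compound 3 and compound 4 both stop at a limit in this assay, so the step between them cannot be read: the limit of > 40000 nM in this assay, at which 3 of the 4 values shown sit. The compounds shown leave open whether hydrogen in place of iodo changes the read-out on the core of compound 3 as it does on the core of compound 1.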